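Replacing a Methoxyphenyl Arm with a Bromophenyl Arm

The source may hold more compounds than are shown below. What is called first, only, known or untested is meant among the compounds shown, and "the series" means these compounds.

Measured compounds:
compound 1, `C=CCn1c(=O)/c(=C\c2cccc(Cl)c2Cl)[nH]c(=O)/c1=C\c1ccccc1OC`, 1600 nM
compound 2, `C=CCn1c(=O)/c(=C\c2ccccc2OC)[nH]c(=O)/c1=C\c1ccccc1OC`, 6900 nM

Compound 2 gives the highest of the two numbers in a functional assay on HeLa cells (Homo sapiens) for cytotoxicity, read by CCK-8 assay, with a stated time of 72 h; a lower number here means a stronger inhibitor, a higher number a weaker inhibitor; its nearest neighbour is compound 1, which differs only on the double-bonded chain carbon bound to an aromatic carbon, and the change there is a 4.3-fold higher number from compound 1 to compound 2 (0.63 log units; beyond the scatter).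

Compound 3, `C=CCn1c(=O)/c(=C\c2cccc(Br)c2)[nH]c(=O)/c1=C\c1ccccc1OC`, has not yet been measured. It is reached from compound 2 by 3-bromophenyl in place of 2-methoxyphenyl on a double-bonded chain carbon bound to an aromatic carbon. Among the measured compounds shown here, only one measured step bears on this move: the step from a dichlorophenyl to a methoxyphenyl on the same carbon, which was a 4.3-fold higher number from compound 1 to compound 2 (0.63 log units; beyond the scatter). Compound 3 goes the other way, taking the methoxyphenyl off again and bringing in a halogen-bearing phenyl, though with one bromine rather than two chlorines and at a different position on that ring. The writer therefore expects a step back toward compound 1, but a smaller one, estimated as a 2.3-fold lower number from compound 2 to compound 3 (0.36 log units; beyond the scatter). Compound 3 is expected to give about 3000 nM in this assay, within a range of 1000 nM to 9000 nM.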

Compound 3, half-maximal inhibitory concentration: 5400 nM
For compound 3 the middle estimate is 1.8-fold (0.26 log units) below the measured one; the range from low to high includes it.
By their numbers in this assay, from the lowest: compound 1; then compounds 3 and 2 (each within the scatter of the next).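

In this assay the 3-bromophenyl and 2-methoxyphenyl arms, on the double-bonded chain carbon bound to an aromatic carbon, cannot be told apart (a 1.3-fold lower number from compound 2 to compound 3 (0.11 log units; within the scatter)). A halogen on this phenyl ring is therefore not enough, in these three compounds, to match the 2,3-dichlorophenyl arm (a 3.4-fold higher number from compound 1 to compound 3 (0.53 log units; beyond the scatter)). Among the compounds shown here, compound 1 stays the strongest of the three, and its advantage now appears tied to the 2,3-dichlorophenyl arm rather than shared by both halogen-bearing phenyl arms, which the single earlier step could not show. No supporting measurement is available to explain these differences.

The compounds shown leave open whether the gap to compound 1 follows the number of halogens, their kind or their place on the ring, as the 3-bromophenyl and 2,3-dichlorophenyl arms differ in all three. Also open, from the compounds shown here alone, is how the arm at this position would fare with an amine or a carboxylic acid on its phenyl ring.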